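One Methoxy Fewer: From Compound 2 to Compound 4

The compounds below may be only part of what the source reports. "The series", "measured", "known", "first", "only" and "open" are said of these compounds alone.

Compound 2 `COc1cc(-c2cc(/C=C/C(=O)c3ccc(N)cc3)[nH]n2)cc(OC)c1OC` gives 85% in a functional assay on OVCAR-4 cells (Homo sapiens) for cytotoxicity, read by sulforhodamine B assay, with a stated time of 48 h, tested at 0.01 uM; a higher number here means a weaker effect of the compound at the concentration tested, a lower number a stronger effect. Its two companions sit within the scatter of it: compound 1 `COc1ccc(-c2cc(/C=C/C(=O)c3ccc(N)cc3)[nH]n2)cc1` gives 88% and compound 3 `COc1ccc(C(=O)/C=C/c2cc(-c3cc(OC)c(OC)c(OC)c3)n[nH]2)cc1OC` gives 95% in this assay. Going by the values given here, the single measured step, a number 10 percentage points higher from compound 2 to compound 3 (within the scatter), alters the group on the carbonyl carbon and stays within the scatter. Compound 4 `COc1ccc(-c2cc(/C=C/C(=O)c3ccc(N)cc3)[nH]n2)cc1OC` differs from compound 2 by hydrogen in place of methoxy on an aromatic carbon. Among the compounds with values here, no measured step removes a methoxy group from that ring, so the step from compound 2 to compound 3 bears on this change only loosely, and all three numbers so far lie high and close together. Compound 4 is therefore expected to give 85%, between 75% and 95%. The expected step, no change at the digits printed from compound 2 to compound 4 (within the scatter), is none beyond the scatter.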

Compound 4, a percentage reported as activity, at one concentration (the size of the read-out at that concentration, not a potency): 85%
For compound 4 middle estimate and measured number coincide at the digits printed, within the range that was stated.
By their numbers in this assay, from the lowest: compounds 2, 4, 1 and 3 (each within the scatter of the next).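

Hydrogen in place of methoxy on this aromatic carbon gives no change at the digits printed from compound 2 to compound 4 (within the scatter) and methoxy in place of hydrogen gives a number 3 percentage points lower from compound 1 to compound 4 (within the scatter) in this assay so the methoxy groups on this ring can now be followed directly in both directions. Neither change leaves the scatter, so these compounds separate on nothing at this concentration. No available measurement offers an explanation for this.

From the compounds shown here alone, whether a hydroxyl group, a fluorine atom or an amine on this aromatic carbon would move the number beyond the scatter stays open. So does whether these methoxy changes would separate at any other concentration.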